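Aminoquinoline ether series: branched alkyl replacing trifluoropropyl

This account rests on a few compounds, and the source may have more. Where it says the series, first, only, none or still open, it means among the compounds named here.

Measured compounds:
compound 1 `Nc1ccc2cccc(OCCC(F)(F)F)c2n1` — 722 nM
compound 2 `CC(CC(C)(C)C)Oc1cccc2ccc(N3CCCC3)nc12` — > 2000 nM

Among the measured compounds shown here, compound 1 gives 722 nM in an assay on cells with melanin-concentrating hormone receptor 1 (Homo sapiens) as the target, read by radioligand binding (a higher number here means a weaker inhibitor, a lower number a stronger inhibitor), the only numeric value in the set. Compound 2 returns a limit in this assay rather than a number, > 2000 nM; this is the limit (the limit of > 2000 nM in this assay, at which 1 of the 2 values shown sits), so nothing more than that can be said of it. For the measured compounds named here, compound 1 and compound 2 differ in two places at once, so their values show only that one is a number and the other a limit.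

Compound 3 `CC(C)C(C)Oc1cccc2ccc(N)nc12` has not been measured. It differs from compound 1 by 1,2-dimethylpropyl in place of 3,3,3-trifluoropropyl on an oxygen on an aromatic ring. Going by the values given here, no measured pair in the set shares this single change, so the size of the step must be estimated without a direct precedent. The expectation is a modest loss in this assay, somewhat beyond the usual scatter, with a real chance that only a limit is reported. For compound 3 the estimated value in this assay is 1500 nM, with a range of 400 nM to 5000 nM. The expected step from compound 1 to compound 3 is a 2.1-fold higher number from compound 1 to compound 3 (0.32 log units; beyond the scatter).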

Compound 3, half-maximal inhibitory concentration: 199 nM
Estimate against measurement, compound 3: 7.5-fold (0.88 log units) above, outside the stated range (below it).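

In this assay, the oxygen-linked group on the shared core proves open to change: 1,2-dimethylpropyl in place of 3,3,3-trifluoropropyl gives a 3.6-fold lower number from compound 1 to compound 3 (0.56 log units; beyond the scatter). Among the compounds shown here, this is the only single-place change that can be read in the set, and it shows that a chain of 5 carbon atoms with no fluorine can stand at this place with a lower number than the fluorinated chain of compound 1; steps involving compound 2 cannot be read, as it differs from compound 1 in two places and its result is a limit. Nothing in the data shown gives a reason for this gain.

With one step, the removal of the fluorine atoms cannot be separated from the introduction of branching, and an unbranched pentyl chain or a cyclopentyl group on the same oxygen would be needed to tell the two apart. Going by these compounds, it also remains open whether the gain seen with 1,2-dimethylpropyl holds when the free amine on the core is replaced by a substituted amine or an amide.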